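Ester Chain Lengthening and Adenosine Receptor Displacement

A few compounds are considered here, and "the series" means these few. Any claim that something is new, unique, unknown or untested is made for them only; others in the source may bear on it.

Compound 1, `CCOC(=O)C1=C(C)NC(=O)NC1C1CCCC1`: 18%
Compound 2, `CCOC(=O)C1=C(C)N/C(=N\C#N)NC1c1ccccc1`: 13%
Compound 3, `CC1=C(C(=O)OC(C)C)C(c2ccccc2)N/C(=N/C#N)N1`: 6%

These three compounds were measured in an assay on HeLa cells for displacement of a labelled ligand from adenosine receptor A3 (Homo sapiens), with a stated time of 180 min, tested at 1 uM; on this read-out higher numbers stand for more inhibition at the one concentration tested (going by the name of the read-out) and lower numbers for less inhibition. Compound 1 and compound 2 lie within the usual scatter of each other, while compound 3 lies beyond the scatter below compound 1. Compound 2 and compound 3 share a core and differ by one change, (methyl in place of hydrogen on a saturated chain carbon bound to an oxygen next to a carbonyl group and a saturated chain carbon), which made a step of a number 7 percentage points lower from compound 2 to compound 3 (within the scatter). Compound 4, `CC1=C(C(=O)OC(C)C)C(C2CCCC2)NC(=O)N1`, carries the same change relative to compound 1, (methyl in place of hydrogen on a saturated chain carbon bound to an oxygen next to a carbonyl group and a saturated chain carbon); the place of the change is the same in both pairs. The difference between the cores of compound 1 and compound 2 is not broken down here. For compound 4 in this assay a step of similar size is expected, a number 7 percentage points lower from compound 1 to compound 4 (within the scatter). Among the compounds with values here, this rests on the single measured example of this change, a number 7 percentage points lower from compound 2 to compound 3 (within the scatter). Compound 4 is therefore estimated at 11%, with a likely range from 0% to 24%.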

Compound 4, a percentage reported as inhibition, at one concentration (the size of the read-out at that concentration, not a potency): 7%
The estimate for compound 4 lay 4 percentage points above the measured number; low and high end bracket the measured number.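

Swapping ethoxycarbonyl for isopropoxycarbonyl in this assay gives a number 11 percentage points lower from compound 1 to compound 4 (beyond the scatter). Set beside the earlier step, the same change lowers the number on both cores, by amounts that do not clearly differ: the same change on two cores in this assay, a number 7 percentage points lower (within the scatter) from compound 2 to compound 3 and a number 11 percentage points lower (beyond the scatter) from compound 1 to compound 4, 4 percentage points apart, within the scatter of two such steps

Within the data shown here, this is only two pairs, read at a single concentration and not as a potency, so it does not show that the change would behave alike on any other core, nor does it explain why the numbers fall.

The compounds shown leave open what a longer chain, such as butoxycarbonyl, would give at this place. They also leave open what a carboxylic acid in place of the ester would give.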